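This account rests on a few compounds, and the source may have more. Where it says the series, first, only, none or still open, it means among the compounds named here.

Compound 1 `CNC(=O)[C@@]12C[C@@H]1[C@@H](n1cnc3c(NC)nc(C#Cc4ccc(Cl)cc4)nc31)[C@H](O)[C@@H]2O`: 13%
Compound 2 `CNC(=O)[C@@]12C[C@@H]1[C@@H](n1cnc3c(NC)nc(C#Cc4ncccn4)nc31)[C@H](O)[C@@H]2O`: 25%

In an assay on CHO cells for displacement of a labelled ligand from adenosine receptor A1 (Homo sapiens), read by scintillation counting, with a stated time of 60 min, tested at 10 uM (on this read-out lower numbers stand for less inhibition and higher numbers for more inhibition at the one concentration tested (going by the name of the read-out)), compound 2 gives 25%, the higher of the two numbers measured. Compound 1 gives 13%. For the measured compounds named here, the single step so far, a number 12 percentage points higher from compound 1 to compound 2 (beyond the scatter), exchanged one six-membered aromatic ring for another on the triple-bonded carbon.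

Compound 3 `CNC(=O)[C@@]12C[C@@H]1[C@@H](n1cnc3c(NC)nc(C#CC4CCCCC4)nc31)[C@H](O)[C@@H]2O` differs from compound 2 by cyclohexyl in place of pyrimidin-2-yl on a triple-bonded carbon. Going by the values given here, no measured step exchanges an aromatic ring for a non-aromatic one at this position, so the one step measured bears on this change only loosely; it shows that a swap of the ring at the end of the ethynyl group moved the number modestly, and in one direction only. Given that, the step of a number 5 percentage points lower from compound 2 to compound 3 (within the scatter) is expected to be small and of uncertain direction. Compound 3 is therefore estimated to give about 20%, with a range from 5% to 42%.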

Compound 3, a percentage reported as inhibition, at one concentration (the size of the read-out at that concentration, not a potency): 15%
Estimate against measurement, compound 3: 5 percentage points above; the measured number falls inside the stated range.
By their numbers in this assay, from the lowest: compounds 1, 3 and 2 (each within the scatter of the next, the first and the last beyond it).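

In this assay, for the compounds shown here, the step with cyclohexyl in place of pyrimidin-2-yl is a number 10 percentage points lower from compound 2 to compound 3 (within the scatter) and the step with cyclohexyl in place of 4-chlorophenyl is a number 2 percentage points higher from compound 1 to compound 3 (within the scatter) and so, for the first time, a non-aromatic ring of carbon only stands at the end of the ethynyl group. Neither step lies beyond the scatter, so among these three compounds an aromatic ring on the triple-bonded carbon is not shown to be required for the number obtained. The hydrogen-bond acceptors of pyrimidin-2-yl, absent from cyclohexyl, likewise go with no step beyond the scatter.

Going by these compounds, how an amine, a carboxylic acid or a longer chain at this place would read stays open. Nothing measured here explains these numbers.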